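Swapping a Fluorophenyl for a Furan on a Shared Core

The source may report more compounds than this note shows. Statements on the series, on what has been measured and on what is new or still open speak of the compounds shown alone.

Of the compounds shown here, three built on one shared core have been measured in a functional assay on MCF7 cells (Homo sapiens) for cytotoxicity, read by MTT assay, with a stated time of 24 h; on this read-out lower numbers stand for stronger inhibition and higher numbers for weaker inhibition. Compound 1 `COc1cccc(/C=C2\SC(=O)N(Cc3ccc(C(=O)O)cc3)C2=O)c1` gives 58000 nM in this assay. Compound 2 `Cc1ccc(/C=C2\SC(=O)N(Cc3ccc(C(=O)O)cc3)C2=O)cc1` gives 100000 nM. Compound 3 `O=C(O)c1ccc(CN2C(=O)S/C(=C\c3ccc(F)cc3)C2=O)cc1` gives 38000 nM, the lowest of the three numbers, though its nearest neighbour sits close: a 1.5-fold lower number from compound 1 to compound 3 (0.18 log units; within the scatter). Among the compounds with values here, only one step lies beyond the scatter: a 2.6-fold lower number from compound 2 to compound 3 (0.42 log units; beyond the scatter). The remaining step, a 1.7-fold higher number from compound 1 to compound 2 (0.24 log units; within the scatter), is within the scatter.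

Compound 4 `O=C(O)c1ccc(CN2C(=O)S/C(=C\c3ccco3)C2=O)cc1` differs from compound 3 in one place: furan-2-yl in place of 4-fluorophenyl on a double-bonded chain carbon bound to a double-bonded ring carbon. Each measured step exchanges the group on that same chain carbon, so all three bear on this change, yet none exchanges a six-membered ring for a five-membered one, so none matches it directly. What they show is that changing the ring at this position moves the number by little, at most modestly. Within the data shown here, a small step in either direction is therefore expected for compound 4, and the estimate stays near compound 3 because a 2.6-fold lower number from compound 2 to compound 3 (0.42 log units; beyond the scatter) is the only step beyond the scatter and is itself modest. Compound 4 is expected to give 45000 nM in this assay, with a range from 18000 nM to 110000 nM. The expected step is a 1.2-fold higher number from compound 3 to compound 4 (0.07 log units; within the scatter), which is estimated to remain within the scatter.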

Compound 4, half-maximal inhibitory concentration: 90000 nM
Estimate against measurement, compound 4: 2.0-fold (0.30 log units) below; the range from low to high includes it.
By their numbers in this assay, from the lowest: compounds 3, 1, 4 and 2 (each within the scatter of the next, the first and the last beyond it).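

Compound 4 brings the first five-membered ring to this position, and replacing 4-fluorophenyl with furan-2-yl gives a step beyond the scatter, a 2.4-fold higher number from compound 3 to compound 4 (0.37 log units; beyond the scatter), though still a modest one. Set against the other two six-membered rings, however, furan-2-yl stands apart from neither, with a 1.1-fold lower number from compound 2 to compound 4 (0.05 log units; within the scatter) and a 1.6-fold higher number from compound 1 to compound 4 (0.19 log units; within the scatter), both within the scatter, so the smaller ring does not by itself separate compound 4 from the compounds carrying a six-membered ring, and the one clear gap is to compound 3 alone. No measurement available here accounts for that gap or says what in the exchange of rings produces it.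

Still open, from the compounds shown here alone, is whether the oxygen of the furan matters or only the ring as a whole, a question that thiophen-2-yl, a five-membered ring with sulfur as its hetero atom, would bear on directly. Going by these compounds, it also remains unknown whether this position needs an aromatic ring at all, or whether a plain propyl chain or a small amine on the same chain carbon would leave the number in the same range.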